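The source may report more compounds than this note shows. Statements on the series, on what has been measured and on what is new or still open speak of the compounds shown alone.

Three compounds of the series have numbers in an assay on isolated protein for inhibition of RAC-alpha serine/threonine-protein kinase (Homo sapiens), tested at 30 uM; on this read-out higher numbers stand for more inhibition at the one concentration tested (going by the name of the read-out) and lower numbers for less inhibition. Compound 1, `Cn1cnc2c(SCc3ccccc3)ncnc21`, gives 4%. Compound 2, `Cn1cnc2c(SCc3ccc(F)cc3)ncnc21`, gives 11% in this assay. Compound 3, `Clc1ncnc2ncn(Cc3ccccc3)c12`, gives 0% in this assay, the lowest of the three numbers; its gap to compound 1 lies within the scatter, its gap to compound 2 beyond it. The difference between the core of compound 1 and the core of compound 3 is not broken down here.

Compound 4, `Fc1ccc(Cn2cnc3ncnc(Cl)c32)cc1`, has not yet been measured in this assay. It is related to compound 3 by the change (fluoro in place of hydrogen on an aromatic carbon). The same change occurs once more among the measured compounds, from compound 1 to compound 2, as fluoro in place of hydrogen on an aromatic carbon; the two place descriptions match word for word, so the change is the same in both pairs. That earlier step gave a number 7 percentage points higher from compound 1 to compound 2 (within the scatter).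

The step expected from this change in compound 4 is a number 5 percentage points higher from compound 3 to compound 4 (within the scatter), similar in size to a number 7 percentage points higher from compound 1 to compound 2 (within the scatter), which did not leave the scatter. Since compound 3 stands at 0%, a rise of that size would still leave compound 4 near the bottom of the range. Compound 4 is estimated at 5% in this assay, with a plausible range from 0% to 15%. The precedent rests on a single pair of compounds, so the expectation carries no weight beyond them, and the measured number for compound 4 will show whether the small step repeats.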

Compound 4, a percentage reported as inhibition, at one concentration (the size of the read-out at that concentration, not a potency): 0%
Compound 4: the middle estimate sits 5 percentage points above what was measured; the measured number falls inside the stated range.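

In this assay, fluoro in place of hydrogen on an aromatic carbon gives no change at the digits printed from compound 3 to compound 4 (within the scatter), and the two readings of this change do not differ: the same change on two cores in this assay, a number 7 percentage points higher (within the scatter) from compound 1 to compound 2 and no change at the digits printed (within the scatter) from compound 3 to compound 4, 7 percentage points apart, within the scatter of two such steps

On the two cores shown, then, the change carries over in the sense that neither step leaves the scatter, so a small or absent step is a fair working expectation for this pair of cores. Within the data shown here, it does not show that fluoro has any effect on inhibition on either core, nor that the two cores respond alike in any finer sense, since neither step is large enough to compare in size, only two pairs are available, and the read-out is a single-concentration percentage that stays low throughout these pairs.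

Still open, as far as these compounds go, is whether anything other than hydrogen or fluoro at this place, para to a large group, would give a step beyond the scatter on either core, for instance an amine or a carboxylic acid on the same six-membered aromatic ring. Also open, from the compounds shown here alone, is what a longer chain between that ring and the core would do, and how the change behaves on a core with a clearly higher starting number.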